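Inverting one stereocentre on a weakly cytotoxic diterpenoid scaffold

A few compounds are considered here, and "the series" means these few. Any claim that something is new, unique, unknown or untested is made for them only; others in the source may bear on it.

Three compounds sharing one core have been examined for cytotoxicity. Compound 1 `C=C1C(=O)[C@H]2C[C@@H]1CC1=C2[C@]2(C)CCC[C@](C)(CO)[C@H]2CC1` carries an exocyclic methylene and a hydroxymethyl group; in a functional assay on SH-SY5Y cells (Homo sapiens) for cytotoxicity, read by MTT assay, with a stated time of 24 h (a higher number here means a weaker inhibitor, a lower number a stronger inhibitor), compound 1 gives 33800 nM. Compound 2 `C[C@@H]1C(=O)[C@H]2C[C@]1(O)CC1=C2[C@]2(C)CCC[C@](C)(CO)[C@H]2CC1` bears instead a methyl group and a tertiary hydroxyl, keeping the hydroxymethyl; in this assay compound 2 reaches only the limit of the assay, > 50000 nM. Compound 3 `C[C@@H]1C(=O)[C@H]2C[C@]1(O)CC1=C2[C@]2(C)CCC[C@](C)(C=O)[C@H]2CC1` has a formyl in place of the hydroxymethyl on a saturated ring carbon; in this assay compound 3 likewise reaches only the limit, > 50000 nM. The step that the two limits leave unreadable from compound 2 to compound 3 therefore cannot be read, because of the limit of > 50000 nM in this assay, at which 2 of the 3 values shown sit.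

Compound 4 `C[C@@H]1C(=O)[C@H]2C[C@]1(O)CC1=C2[C@]2(C)CCC[C@@](C)(CO)[C@H]2CC1` is the stereoisomer of compound 2: the two compounds have the same atoms and bonds and differ only in configuration as drawn: 1 of 6 stereo elements differ; a stereocentre at a saturated ring carbon is drawn S in compound 2 and R in compound 4. Within the data shown here, no measured step addresses a change in configuration alone, and the only measured step from compound 2 is unreadable, so there is no direct guide to its size or direction. With compound 2 sitting at the limit, compound 4 is expected to stay in the same weak region, and the step of a number no higher from compound 2 to compound 4 (the limit leaves the size open) is estimated to lie within the scatter. In this assay compound 4 is accordingly estimated at 50000 nM, within the range 20000 nM to 120000 nM.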

Compound 4, half-maximal inhibitory concentration: > 50000 nM
Compound 4: only a limit was reported; the forecaster's own chance of this, stated with the estimate: 70%; the middle value sits exactly at the limit.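

In this assay compound 4 gives > 50000 nM which is only a limit of the assay. The change in configuration between compound 2 and compound 4 therefore cannot be read: (the limit of > 50000 nM in this assay, at which 3 of the 4 values shown sit). The compounds shown leave open whether in this assay the configuration at that saturated ring carbon has any bearing on cytotoxicity.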